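The source may report more compounds than this note shows. Statements on the series, on what has been measured and on what is new or still open speak of the compounds shown alone.

In a functional assay on SGC-7901 cells (Homo sapiens) for cytotoxicity, read by MTT assay, with a stated time of 48 h (a lower number here means a stronger inhibitor, a higher number a weaker inhibitor), compound 2, `O=C(CSc1ccc(Br)cc1)N1N=C(c2cc3ccccc3oc2=O)C[C@@H]1c1ccc(C(F)(F)F)cc1`, gives 12100 nM. Among the measured compounds shown here, only one other compound has been measured there, compound 1, `CC1=NN(C(=O)CSc2ccccc2)[C@@H](c2cc(Br)cc(Br)c2O)C1`, and in this assay compound 1 gives 24100 nM. The number for compound 2 reads lower of the two, but the gap between them lies within the scatter, so no real order between compound 1 and compound 2 can be claimed. Compound 3, `CCCCSCC(=O)N1N=C(c2cc3ccccc3oc2=O)C[C@@H]1c1ccc(C(F)(F)F)cc1`, has not been measured in this assay. It departs from compound 2 in a single place: butyl in place of 4-bromophenyl on a sulfur. For the measured compounds named here, no measured pair shows a change of this kind, so nothing sets its size. Compound 3 is therefore expected to stay close to compound 2, with a 1.3-fold higher number from compound 2 to compound 3 (0.12 log units; within the scatter) leaning slightly toward weaker inhibition. Compound 3 is estimated at 16000 nM, within a range from 5000 nM to 50000 nM.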

Compound 3, half-maximal inhibitory concentration: 2910 nM
Beside the measured number, compound 3's estimate is 5.5-fold (0.74 log units) above it; the measured number lies below the stated range.
By their numbers in this assay, from the lowest: compound 3; then compounds 2 and 1 (each within the scatter of the next).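

In this assay, the group on the sulfur proves able to move the number: butyl in place of 4-bromophenyl gives a 4.2-fold lower number from compound 2 to compound 3 (0.62 log units; beyond the scatter), a modest step but one beyond the scatter. Among the compounds shown here, this is the first step read at this position, and it shows that, with the rest of compound 2 unchanged, an aromatic ring on the sulfur is not required, as the chain with no ring gives the lower number. No measured finding bears on this step, so it stands without an explanation.

Going by these compounds, whether the lower number belongs to the butyl chain itself or to the loss of 4-bromophenyl stays open; an ethyl or a longer hexyl chain on the same sulfur would help separate the two. On these data alone, it also remains open whether butyl would give a similar step on the core of compound 1.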